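Phenyl in place of ethyl on compound 1

The source may hold more compounds than are shown below. What is called first, only, known or untested is meant among the compounds shown, and "the series" means these compounds.

In an ADME assay on H9c2 cells (Rattus norvegicus) for cytotoxicity (on this read-out lower numbers stand for higher toxicity in this test and higher numbers for lower toxicity in this test), compound 1 `CCCCC(=O)Nc1nc2ccccc2n1CCC` gives 25000 nM, compound 2 `CCCCCCCCC(=O)Nc1nc2ccccc2n1CCC` gives 20000 nM and compound 3 `CCCn1c(NC(=O)/C=C/c2ccccc2)nc2ccccc21` gives 20000 nM. Compound 1 therefore does not stand apart, since both other numbers lie within the usual scatter of its own.

The next compound to be tested is compound 4 `CCCn1c(NC(=O)CCc2ccccc2)nc2ccccc21`. The difference from compound 1 is phenyl in place of ethyl on a saturated chain carbon, two bonds along the chain from a carbonyl carbon.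

Within the data shown here, only one measured step bears directly on this chain, namely a 1.3-fold lower number from compound 1 to compound 2 (0.10 log units; within the scatter), so lengthening the chain by butyl left the number within the scatter. Compound 3 also carries a phenyl, and its 20000 nM is likewise within the scatter of compound 1. No step beyond the scatter is therefore expected in this assay, and the estimated change is a 1.3-fold lower number from compound 1 to compound 4 (0.10 log units; within the scatter). Compound 4 is expected to give about 20000 nM, within an estimated range of 10000 nM to 40000 nM.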

Compound 4, half-maximal cytotoxic concentration: > 50000 nM
Compound 4 was reported as a limit; the forecaster's own chance of this, stated with the estimate: 15%; middle value at least 2.5-fold (0.39 log units) from the limit.
By their numbers in this assay, from the lowest: compounds 2, 3 and 1 (each within the scatter of the next). At a limit, above all of these: compound 4.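

In this assay compound 4 is reported as a limit and not as a number: the limit of > 50000 nM in this assay, at which 1 of the 4 values shown sits. At this place, on a saturated chain carbon, two bonds along the chain from a carbonyl carbon, phenyl in place of hexyl gives an at least 2.5-fold higher number from compound 2 to compound 4 (0.39 log units; beyond the scatter), the only step shown that is known to go beyond the scatter, and on this read-out it points to lower toxicity in this test. Phenyl in place of ethyl gives an at least 2.0-fold higher number from compound 1 to compound 4 (0.30 log units; that floor lies within the scatter), so that floor alone does not separate compound 4 from compound 1, though the true gap may be larger.

As far as these compounds go, how far the true number of compound 4 lies from its limit stays open. So does whether another ring, or an amine or a carboxylic acid in place of the phenyl, would give the same result.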